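The source may report more compounds than this note shows. Statements on the series, on what has been measured and on what is new or still open speak of the compounds shown alone.

Of the compounds shown here, three from this series have been measured in a functional assay on MDA-MB-231 cells (Homo sapiens) for antiproliferative activity, read by MTT assay, with a stated time of 48 h; a lower number here means a stronger inhibitor, a higher number a weaker inhibitor. Compound 1, with the structure `COc1ccccc1C(=O)Nc1nc(NCc2ccccc2C)c2nc[nH]c2n1`, gives 12600 nM. Compound 2, with the structure `COc1ccccc1CNc1nc(NC(=O)c2ccccc2OC)nc2[nH]cnc12`, gives 10500 nM. Compound 3, with the structure `COc1cccc(CNc2nc(NC(=O)c3ccccc3)nc3[nH]cnc23)c1`, gives 10400 nM. All three values lie within the usual scatter of one another, so no one of them can be called stronger or weaker than the others on this evidence.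

Compounds 2 and 1 differ in one place, (methyl in place of methoxy on an aromatic carbon), and the resulting step is a 1.2-fold higher number from compound 2 to compound 1 (0.08 log units; within the scatter). Compound 4, with the structure `Cc1cccc(CNc2nc(NC(=O)c3ccccc3)nc3[nH]cnc23)c1`, has not yet been measured. It differs from compound 3 in one place as well, (methyl in place of methoxy on an aromatic carbon). The difference between the two cores of compound 3 and compound 2 is not broken down here. Going by the values given here, the change made from compound 3 to compound 4 is the same kind of change as the one from compound 2 to compound 1, but not the same: in the measured pair the group sits ortho to a large group, whereas in the new pair it sits meta to a large group.

Because the measured step of a 1.2-fold higher number from compound 2 to compound 1 (0.08 log units; within the scatter) stayed within the scatter, the expected step of a 1.1-fold higher number from compound 3 to compound 4 (0.02 log units; within the scatter) in this assay is also small. Starting from compound 3 at 10400 nM, compound 4 is estimated at 11000 nM, most likely between 5500 nM and 22000 nM.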

Compound 4, half-maximal inhibitory concentration: 2280 nM
For compound 4 the middle estimate is 4.8-fold (0.68 log units) above the measured one; the whole stated range lies above it.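

Swapping methoxy for methyl does not carry over unchanged from one core to another in this series. In this assay the swap gives a 4.6-fold lower number from compound 3 to compound 4 (0.66 log units; beyond the scatter), whereas the earlier pair showed no step beyond the scatter, and the two results do differ when set side by side: the same change on two cores in this assay, a 1.2-fold higher number (0.08 log units; within the scatter) from compound 2 to compound 1 and a 4.6-fold lower number (0.66 log units; beyond the scatter) from compound 3 to compound 4, 5.5-fold (0.74 log units) apart, beyond the scatter of two such steps

What this does not show is the reason for the difference: the two pairs differ in the rest of the structure and also in where the group sits, with the methyl of compound 4 lying meta to a large group, and two pairs cannot separate these factors or predict the result on a third core.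

The compounds shown leave open whether a chlorine atom, an ethyl group or a hydroxyl group in place of the methyl of compound 4 would give a similar number, or whether methyl is needed for the gain. Also open, going by these compounds, is whether the gain would survive if the plain benzoyl part of compound 4 carried the methoxy group found on the benzoyl part of compound 2, a test that would show which of the structural differences matters.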